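The compounds below may be only part of what the source reports. "The series", "measured", "known", "first", "only" and "open" are said of these compounds alone.

In a physicochemical assay, with a stated time of 10 min (on this read-out higher numbers stand for weaker inhibition and lower numbers for stronger inhibition), compound 1 `C/C(=N/N=C1\SCC(=O)N1Cc1ccc(F)cc1)c1ccccn1` gives 3670000 nM and compound 2 `C/C(=N\N=C1/SCC(=O)N1Cc1cccc(Cl)c1)c1ccccn1` gives 2760000 nM as its value, and these two lie within the usual scatter of each other. Compound 3 `O=C1CS/C(=N\N=C2CCCC2)N1Cc1ccccc1F` stands at > 5000000 nM as a limit of this assay and not a number. Compound 4 `O=C1CS/C(=N\N=C2CCCC2)N1Cc1ccc(Cl)cc1` carries 4-chlorophenyl in place of 2-fluorophenyl on a saturated chain carbon bound to an amide-type nitrogen in a ring and keeps the rest of compound 3 unchanged. For the measured compounds named here, no measured pair differs in one place, so only a small move toward stronger inhibition in this assay is expected, hardly beyond the scatter, and the estimated change is an at least 1.2-fold lower number from compound 3 to compound 4 (0.09 log units; that floor lies within the scatter) on this read-out. For compound 4 the expected value is 4000000 nM within an estimated range from 2000000 nM to 8000000 nM on this read-out.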

Compound 4, half-maximal inhibitory concentration: > 5000000 nM
Compound 4 ended at the assay's limit; the forecaster's own chance of this, stated with the estimate: 45%; middle value at least 1.2-fold (0.09 log units) away from the limit.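

No step can be read from compound 3 to compound 4, because both end at the same assay limit rather than at a number: the limit of > 5000000 nM in this assay, at which 2 of the 4 values shown sit.

The compounds shown leave open whether 4-chlorophenyl in place of 2-fluorophenyl changes inhibition at all in this assay.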